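The compounds below may be only part of what the source reports. "The series", "measured", "known", "first", "only" and "open" are said of these compounds alone.

Compound 1 `O=C(c1ccc(F)cc1)N1CCC(NCCSC(c2ccc(F)cc2)c2ccc(F)cc2)CC1` gives 32.1 nM in an assay on membranes from Cortex for displacement of a labelled ligand from Sigma non-opioid intracellular receptor 1 (Cavia porcellus), read by scintillation counting, with a stated time of 120 min; a lower number here means a stronger inhibitor, a higher number a weaker inhibitor. Compound 2 `CC(C)(C)C(=O)N1CCC(NCCSC(c2ccc(F)cc2)c2ccc(F)cc2)CC1` gives 163 nM in this assay, and compound 3 `CC(C)(C)CN1CCC(NCCSC(c2ccc(F)cc2)c2ccc(F)cc2)CC1` gives 315 nM. On these three numbers compound 3 stands highest; its gap to compound 2 lies within the scatter, while the step of a 9.8-fold higher number from compound 1 to compound 3 (0.99 log units; beyond the scatter) is beyond it. The step of a 5.1-fold higher number from compound 1 to compound 2 (0.71 log units; beyond the scatter) and the step of a 1.9-fold higher number from compound 2 to compound 3 (0.29 log units; within the scatter) split that larger change into two parts, of which only the first is beyond the scatter.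

Compound 4 `O=C(c1ccc(F)cc1F)N1CCC(NCCSC(c2ccc(F)cc2)c2ccc(F)cc2)CC1` carries (2,4-difluorophenyl)carbonyl in place of neopentyl on an amine nitrogen in a ring. Among the compounds with values here, this reverses the change from compound 1 to compound 3, apart from the additional fluorine counted in the entering group, for which no measured step exists. The step that bears on it is therefore a 9.8-fold higher number from compound 1 to compound 3 (0.99 log units; beyond the scatter), read backwards, with a 1.9-fold higher number from compound 2 to compound 3 (0.29 log units; within the scatter) as a smaller partial reading of the same move. A drop of roughly that size is expected in this assay, bringing compound 4 back close to the number of compound 1. Compound 4 is estimated at 40 nM, in the range 15 nM to 110 nM. The expected step is a 7.9-fold lower number from compound 3 to compound 4 (0.90 log units; beyond the scatter).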

Compound 4, inhibition constant: 20.6 nM
Compound 4: middle estimate off by 1.9-fold (0.29 log units), on the high side; the range from low to high includes it.
By their numbers in this assay, from the lowest: compounds 4 and 1 (each within the scatter of the next); then compounds 2 and 3 (each within the scatter of the next).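

In this assay, (2,4-difluorophenyl)carbonyl in place of neopentyl on the amine nitrogen in the ring gives a 15-fold lower number from compound 3 to compound 4 (1.18 log units; beyond the scatter), so the low number of compound 1 is no longer a single case: two aromatic carbonyl groups now sit in the same range at this position. With the carbonyl held constant, 2,4-difluorophenyl in place of tert-butyl gives a 7.9-fold lower number from compound 2 to compound 4 (0.90 log units; beyond the scatter), which, together with a 5.1-fold higher number from compound 1 to compound 2 (0.71 log units; beyond the scatter), ties the gain at this position to the aromatic ring on the carbonyl carbon and not to the carbonyl alone. Fluoro in place of hydrogen on the aromatic ring gives a 1.6-fold lower number from compound 1 to compound 4 (0.19 log units; within the scatter), so the additional fluorine produces no readable change in this assay.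

Nothing available explains the size of these steps. Still open, as far as these compounds go, is whether a benzyl group on the ring nitrogen, which keeps an aromatic ring but has no carbonyl, would stay in the range of compound 1 and compound 4, and whether an unsubstituted benzoyl or a pyridine-carbonyl group would do the same.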